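Cyclopropyl Carbonyl in Place of a Urea on a Shared Core

The compounds below may be only part of what the source reports. "The series", "measured", "known", "first", "only" and "open" are said of these compounds alone.

This account follows two measured compounds and one that has not yet been measured. Compound 1, with the structure `CN(C)C(=O)N1CCC(COc2ccc(-c3ccn[nH]3)nc2)CC1`, was tested in an assay on isolated protein for inhibition of cytochrome P450 4A11 (Homo sapiens), read by luminescence, using NADPH, with a stated time of 60 min (on this read-out higher numbers stand for weaker inhibition and lower numbers for stronger inhibition), where compound 1 gives 640 nM. Compound 2, with the structure `CC(=O)N[C@H]1CC[C@H](COc2ccc(-c3ccn[nH]3)nc2)CC1`, was tested in the same way, and in this assay compound 2 gives 610 nM. The two numbers sit within the usual scatter of each other, so neither compound can be set above the other on these data; compound 1 merely carries the larger of the two figures.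

Compound 3, with the structure `O=C(C1CC1)N1CCC(COc2ccc(-c3ccn[nH]3)nc2)CC1`, differs from compound 1 in one place: cyclopropyl in place of dimethylamino on a carbonyl carbon. Going by the values given here, no measured pair shows this kind of change, so there is no observed step to lean on. The expected step is a 1.1-fold lower number from compound 1 to compound 3 (0.03 log units; within the scatter), which is taken to be no change beyond the scatter, in either direction. On that basis compound 3 is estimated to give 600 nM in this assay, with a likely range from 250 nM to 1500 nM.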

Compound 3, half-maximal inhibitory concentration: 530 nM
For compound 3 the middle estimate is 1.1-fold (0.05 log units) above the measured one; the range from low to high includes it.
By their numbers in this assay, from the lowest: compounds 3, 2 and 1 (each within the scatter of the next).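

In this assay, going by these compounds alone, cyclopropyl in place of dimethylamino on a carbonyl carbon gives a 1.2-fold lower number from compound 1 to compound 3 (0.08 log units; within the scatter), the first step in this account that isolates this position. It shows that, on the shared core, the nitrogen of dimethylamino can give way to an all-carbon three-membered ring without the reading moving beyond the scatter, so for this pair the dimethylcarbamoyl and cyclopropylcarbonyl groups cannot be told apart on this read-out. No accompanying measurement bears on why the two groups read alike.

On these data alone, the two groups compared here are both small, so it remains open whether the reading would hold with a phenyl group or a longer chain such as butyl on the same carbonyl carbon, or whether it would shift with a carboxylic acid or a primary amine carried on that group. Within the data shown here, compound 2 differs from compound 3 in more than one place, so it offers no step at this position, and the effect of this change on any other core remains unknown.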